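The compounds below may be only part of what the source reports. "The series", "measured", "known", "first", "only" and "open" are said of these compounds alone.

Of the compounds shown here, two have so far been measured in a physicochemical assay for solubility, read by HPLC, with a stated time of 24 h; a lower number here means a less soluble compound, a higher number a more soluble compound. Compound 1 `COC(=O)CC1CCN(C[C@H]2CN(c3ccc(-n4cc(-c5ccccn5)cn4)c(F)c3)C(=O)O2)CC1` gives 92100 nM in this assay. Compound 2 `CCC(=O)NC[C@H]1CN(c2ccc(-n3cc(-c4ccccn4)cn3)c(F)c2)C(=O)O1` gives 147000 nM in this assay, which is the highest of the two numbers measured, though the step of a 1.6-fold higher number from compound 1 to compound 2 (0.20 log units; within the scatter) is no bigger than repeated measurements of a single compound would scatter, so the two compounds cannot be told apart on solubility. Compound 3 `CNC(=O)[C@H]1CN(c2ccc(-n3cc(-c4ccccn4)cn3)c(F)c2)C(=O)O1` differs from compound 2 in one place: methylcarbamoyl in place of (propanoylamino)methyl on a saturated ring carbon. Going by the values given here, the only measured step, a 1.6-fold higher number from compound 1 to compound 2 (0.20 log units; within the scatter), altered a group on a saturated chain carbon rather than on the saturated ring carbon of the shared core, and it stayed within the scatter, so it offers little direct guidance for the new change. With no measured step beyond the scatter pointing in either direction, compound 3 is expected to stay close to compound 2, and the expected step of a 1.2-fold lower number from compound 2 to compound 3 (0.09 log units; within the scatter) lies within the scatter. Compound 3 is therefore estimated at 120000 nM in this assay, with a likely range from 50000 nM to 300000 nM.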

Compound 3, solubility: 26200 nM
Estimate against measurement, compound 3: 4.6-fold (0.66 log units) above, and the stated range ends above it.
By their numbers in this assay, from the lowest: compound 3; then compounds 1 and 2 (each within the scatter of the next).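

On the saturated ring carbon next to the ring oxygen, the group matters in this assay: methylcarbamoyl in place of (propanoylamino)methyl gives a 5.6-fold lower number from compound 2 to compound 3 (0.75 log units; beyond the scatter), whereas a 1.6-fold higher number from compound 1 to compound 2 (0.20 log units; within the scatter) stays within the scatter. Methylcarbamoyl in place of the much larger (4-((methoxycarbonyl)methyl)piperidin-1-yl)methyl gives a 3.5-fold lower number from compound 1 to compound 3 (0.55 log units; beyond the scatter), so compounds 1 and 2, whose groups both reach the ring carbon through a methyl link, sit together, while compound 3, with the smallest group by heavy atoms and no such link, stands apart. The data at hand offer no measurement that explains this separation.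

Compound 3 differs from compound 2 in several ways at once, as it loses the methyl link, turns the amide around and shortens the chain, and these compounds cannot show which of these changes goes with the lower number. A hydroxymethyl or aminomethyl group, or a longer amide such as ethylcarbamoyl, on this same ring carbon would help to pull these features apart.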